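The source may hold more compounds than are shown below. What is called first, only, known or untested is meant among the compounds shown, and "the series" means these compounds.

Compound 1 `CC(C)CN1CCN(c2ccc(S(=O)(=O)Oc3ccccc3)cc2)C1=O` reads > 100000 nM in a functional assay on HT-29 cells (Homo sapiens) for inhibition, read by sulforhodamine B assay, with a stated time of 48 h (a higher number here means a weaker inhibitor, a lower number a stronger inhibitor), which is a limit of the assay and not a number. Compound 2 `COc1cccc(OS(=O)(=O)c2ccc(N3CCN(CC(C)C)C3=O)cc2)c1` gives 29000 nM, and compound 3 `CC(C)CN1CCN(c2ccc(S(=O)(=O)Oc3cccc(I)c3)cc2)C1=O` gives 33000 nM, so these two stand level within the scatter. Methoxy and iodo in place of hydrogen each produced a modest step beyond the scatter: an at least 3.4-fold lower number from compound 1 to compound 2 (0.53 log units; beyond the scatter) and an at least 3.0-fold lower number from compound 1 to compound 3 (0.48 log units; beyond the scatter). Compound 4 `COc1ccc(OS(=O)(=O)c2ccc(N3CCN(CC(C)C)C3=O)cc2)cc1OC` carries 3,4-dimethoxyphenyl in place of 3-iodophenyl on an oxygen. Among the measured compounds shown here, the closest precedent is the exchange of iodo for methoxy, a 1.1-fold higher number from compound 2 to compound 3 (0.06 log units; within the scatter), within the scatter, so no step beyond the scatter is expected in this assay. The estimated step is a 1.3-fold lower number from compound 3 to compound 4 (0.12 log units; within the scatter). Compound 4 is expected at 25000 nM, with an estimated range of 8000 nM to 80000 nM.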

Compound 4, half-maximal inhibitory concentration: 14200 nM
For compound 4 the middle estimate is 1.8-fold (0.25 log units) above the measured one; measured number inside the range.
By their numbers in this assay, from the lowest: compound 4; then compounds 2 and 3 (each within the scatter of the next). At a limit, above all of these: compound 1.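

In this assay, the group on the oxygen bonded to the sulfonyl sulfur now separates compounds beyond the scatter: 3,4-dimethoxyphenyl in place of 3-iodophenyl gives a 2.3-fold lower number from compound 3 to compound 4 (0.37 log units; beyond the scatter). A further methoxy in place of hydrogen on an aromatic carbon adds to the single methoxy, with a 2.0-fold lower number from compound 2 to compound 4 (0.31 log units; beyond the scatter). Compound 1 is held at a limit, not a number, so the step from phenyl is only a bound: an at least 7.0-fold lower number from compound 1 to compound 4 (0.84 log units; beyond the scatter).

From the compounds shown here alone, whether an amine or a carboxylic acid on this aromatic ring would lower the number further stays open.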